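The source may report more compounds than this note shows. Statements on the series, on what has been measured and on what is new or still open speak of the compounds shown alone.

Compound 3 `COc1cc(C(=O)N/N=C/c2c(Cl)cccc2Cl)cc(OC)c1OC` stands second highest of the three numbers in a functional assay on PC-3 cells (Homo sapiens) for antiproliferative activity, read by MTT assay, tested at 1 uM (a lower number here means a weaker effect, a higher number a stronger effect of the compound at the concentration tested), where compound 3 gives 43%. The nearest number is that of compound 1 `COc1cc(C(=O)N/N=C/c2ccc(F)c(F)c2)cc(OC)c1OC`, which in this assay gives 35.1%; the furthest is that of compound 2 `COc1cc(C(=O)N/N=C/c2ccc(C(F)(F)F)cc2)cc(OC)c1OC`, which gives 59.9%. The step to compound 4 `COc1cc(C(=O)N/N=C/c2ccc(F)cc2)cc(OC)c1OC` alters the group on the carbon with a double bond to nitrogen: 4-fluorophenyl in place of 2,6-dichlorophenyl on a carbon with a double bond to nitrogen. Going by the values given here, the one measured step that bears on it is a number 7.9 percentage points higher from compound 1 to compound 3 (within the scatter), a change of the same kind at the same place, and it lies within the scatter. Among the compounds with values here, compound 2 shows a number beyond the scatter from compound 3, but no single step leads to it. The expectation is therefore a step of a number 5 percentage points lower from compound 3 to compound 4 (within the scatter), not beyond the scatter. For compound 4 the estimated value is 38%, with a range from 24% to 54%.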

Compound 4, a percentage reported as inhibition, at one concentration (the size of the read-out at that concentration, not a potency): 76%
Compound 4: middle estimate off by 38 percentage points, on the low side; measured number outside the range, above it.
By their numbers in this assay, from the lowest: compounds 1 and 3 (each within the scatter of the next); then compound 2; then compound 4.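

In this assay, the group on the carbon with a double bond to nitrogen proves able to move the number far beyond the scatter: a number 33 percentage points higher from compound 3 to compound 4 (beyond the scatter) comes with 4-fluorophenyl in place of 2,6-dichlorophenyl. One substituent alone also counts, since a number 40.9 percentage points higher from compound 1 to compound 4 (beyond the scatter) follows hydrogen in place of fluoro on an aromatic carbon, and a number 16.1 percentage points higher from compound 2 to compound 4 (beyond the scatter) follows fluoro in place of trifluoromethyl there. No measurement given here accounts for these steps. From the compounds shown here alone, whether unsubstituted phenyl, or an amine or methoxy group on this ring, would hold the number remains open.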